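Sulfonamide aryl change on a pyrazole core: phenyl to 2,6-dichlorophenyl

The source may hold more compounds than are shown below. What is called first, only, known or untested is meant among the compounds shown, and "the series" means these compounds.

Compound 2 `CC(C)Cc1cc(CNS(=O)(=O)c2ccccc2)nn1-c1ccccc1` carries an unsubstituted phenyl on the sulfonyl sulfur of its sulfonamide. Going by these compounds, in a functional assay on HeLa cells for antagonist activity at 5-hydroxytryptamine receptor 6 (Homo sapiens), read by HTRF and cAMP accumulation, with stated times of 10 min and 30 min (a lower number here means a stronger inhibitor, a higher number a weaker inhibitor), compound 2 gives "not determined" (no result reported): no result was reported for it, so its standing on this read-out is unknown. The only measured point of reference is compound 1 `CC(C)Cc1cc(CNS(=O)(=O)c2cccc(Cl)c2)nn1-c1ccccc1`, which carries a chlorine-bearing phenyl on the same sulfur and in this assay gives 10900 nM, a weak result. Compound 3 `CC(C)Cc1cc(CNS(=O)(=O)c2c(Cl)cccc2Cl)nn1-c1ccccc1` is the unmeasured compound of interest; the difference from compound 2 is 2,6-dichlorophenyl in place of phenyl on a sulfonyl sulfur. Among the measured compounds shown here, since no measured step between two compounds is available, the size of this change in this assay cannot be read from a neighbouring pair. Given that the one related compound, compound 1, is weak at 10900 nM, the expectation is that compound 3 stays in the same weak region, with no step beyond the scatter anticipated in either direction. Compound 3 is therefore estimated at 10000 nM, with a plausible range from 3000 nM to 40000 nM.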

Compound 3, half-maximal inhibitory concentration: 5650 nM
Estimate against measurement, compound 3: 1.8-fold (0.25 log units) above; low and high end bracket the measured number.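

In this assay, compound 3 gives a second measured point on the sulfonyl sulfur: 2,6-dichlorophenyl in place of 3-chlorophenyl gives a 1.9-fold lower number from compound 1 to compound 3 (0.29 log units; within the scatter), so the two chlorine-bearing aryl groups cannot be told apart on this read-out and both compounds remain in the same weak region. Going by these compounds, the step from compound 2 to compound 3 cannot be read: compound 2 has no reported result, and what the unsubstituted phenyl gives on this read-out stays unknown. Nothing at hand bears on why compound 1 and compound 3 read alike.

The compounds shown leave open whether a methoxy group, an amine or a carboxylic acid on the aryl ring attached to the sulfonyl sulfur would move the number beyond the scatter. They also leave open whether a change elsewhere, such as a longer chain in place of the alkyl chain on the shared core, would bring the number out of this weak region.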